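Working notes: the step from compound 3 to compound 4

The compounds below may be only part of what the source reports. "The series", "measured", "known", "first", "only" and "open" are said of these compounds alone.

The measured part of this series consists of compound 1 `CCCC[C@@H](CO)n1cc(C(=O)O)c(=O)c2cc(Cc3cccc(Cl)c3F)c(OC)nc21`, compound 2 `COc1nc2c(cc1Cc1cccc(Cl)c1F)c(=O)c(C(=O)O)cn2[C@H](CO)CC(C)C` and compound 3 `COc1nc2c(cc1Nc1ccc(Cl)c(F)c1)c(=O)c(C(=O)O)cn2[C@H](CO)C(C)C`. For compound 1, an ADME assay on microsomes from liver (Homo sapiens) for metabolic stability, with a stated time of 30 min (a higher number here means that more of the compound is left, a lower number that less of the compound is left), records "not determined" (no result reported). Among the measured compounds shown here, for compound 2, the same read-out gives 92%, the only number so far. For compound 3, it records "not determined" (no result reported), so compound 3 has no position on the scale.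

The next compound is compound 4 `COc1nc2c(cc1NCc1ccccc1F)c(=O)c(C(=O)O)cn2[C@H](CO)C(C)C`, and the change is 2-fluorobenzyl in place of 4-chloro-3-fluorophenyl on a nitrogen on an aromatic ring. In other words, (4-chloro-3-fluorophenyl)amino gives way to (2-fluorobenzyl)amino, on a nitrogen on an aromatic ring.

For the measured compounds named here, no measured pair shows what such a change does in this assay, and without a number for compound 3, no step from it can be read directly. Going by the values given here, the only anchor is compound 2 at 92%, which differs from compound 4 in more than one place, so the expectation is weakly founded. A modest downward shift from the level of compound 2 is expected, possibly no larger than the usual scatter, and the range is kept wide.

Compound 4 is expected at 82%, with an estimated range of 60% to 98%.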

Compound 4, percent of the compound remaining: 97%
For compound 4 the middle estimate is 15 percentage points below the measured one; the range from low to high includes it.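

In this assay, among the compounds shown here, compound 4 gives 97%, while compound 3 has no single number, so no step between compound 3 and compound 4 can be read. No supporting information bears on this result. The compounds shown leave open what 2-fluorobenzyl in place of 4-chloro-3-fluorophenyl on a nitrogen on an aromatic ring does in this assay.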